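The source may report more compounds than this note shows. Statements on the series, on what has been measured and on what is new or still open speak of the compounds shown alone.

Series notes. Compound 3 `O=c1nc(N2CCN(NCc3ccc(Cl)cc3)CC2)sc2c([N+](=O)[O-])cc(C(F)(F)F)cc12` is known in an ADME assay on Vero cells (Chlorocebus sabaeus) for cytotoxicity, read by MTT assay, with a stated time of 72 h (a lower number here means that less compound is tolerated, a higher number that more compound is tolerated), only as a limit of the assay: in this assay compound 3 gives > 64 ug/mL. Compound 1 `O=c1nc(N2CCN(NC3CCCCC3)CC2)sc2c([N+](=O)[O-])cc(C(F)(F)F)cc12` likewise stops at a limit, and compound 1 gives > 64 ug/mL. Compound 2 `O=c1nc(N2CCN(NCc3ccc(OC(F)(F)F)cc3)CC2)sc2c([N+](=O)[O-])cc(C(F)(F)F)cc12` also reaches only a limit, where compound 2 gives > 64 ug/mL. With all three values sitting at the limit of > 64 ug/mL in this assay, at which 3 of the 3 values shown sit, the steps a step that the two limits leave unreadable from compound 1 to compound 2, a step that the two limits leave unreadable from compound 1 to compound 3 and a step that the two limits leave unreadable from compound 2 to compound 3 cannot be read in size or direction.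

The next compound, compound 4 `O=c1nc(N2CCN(Nc3ccc(OC(F)(F)F)cc3)CC2)sc2c([N+](=O)[O-])cc(C(F)(F)F)cc12`, differs from compound 3 by 4-(trifluoromethoxy)phenyl in place of 4-chlorobenzyl on an amine nitrogen. Among the measured compounds shown here, none of the measured steps carries this exact change; the two exchanges of the group on the same amine nitrogen and the exchange of the ring substituent are all unreadable, and nothing among them argues for a loss of tolerance. The step expected in this assay is therefore a step that the limit leaves unreadable from compound 3 to compound 4, none beyond the scatter. The estimate for compound 4 in this assay is 80 ug/mL, between 40 ug/mL and 200 ug/mL, most probably again reported only as a limit.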

Compound 4, half-maximal cytotoxic concentration: > 64 ug/mL
Compound 4 was reported as a limit; the forecaster's own chance of this, stated with the estimate: 80%; the middle value lies beyond the limit too.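

In this assay compound 4 gives > 64 ug/mL as a limit of the assay. Among the compounds shown here, no step among compound 1, compound 2, compound 3 and compound 4 can be read in size or direction: the limit of > 64 ug/mL in this assay, at which 4 of the 4 values shown sit. The compounds shown leave open how much of each is tolerated beyond this limit, and whether the exchanges on the amine nitrogen alter it at all.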